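Swapping the imidazole substituent in a receptor-binding series

This account rests on a few compounds, and the source may have more. Where it says the series, first, only, none or still open, it means among the compounds named here.

Measured compounds:
compound 1 `Cn1cnc(CN2CCN(c3cccc4[nH]c(-c5ccc(C(C)(C)C)cc5)nc34)CC2)c1` gives 33 nM in an assay on isolated protein for displacement of a labelled ligand from Gonadotropin-releasing hormone receptor (Homo sapiens); on this read-out higher numbers stand for weaker inhibition and lower numbers for stronger inhibition
compound 2 `Cc1nc(CN2CCN(c3cccc4[nH]c(-c5ccc(C(C)(C)C)cc5)nc34)CC2)c(C)s1` gives 21 nM in this assay

Among the compounds with values here, compound 1 holds the higher of the two numbers in this assay; the only other compound, compound 2, sits a 1.6-fold lower number from compound 1 to compound 2 (0.20 log units; within the scatter) away, which is within the scatter, so the two cannot be ranked against each other.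

Compound 3 `CCCCn1cnc(CN2CCN(c3cccc4[nH]c(-c5ccc(C(C)(C)C)cc5)nc34)CC2)c1C` has not yet been measured. It differs from compound 1 in one place: 1-butyl-5-methyl-1H-imidazol-4-yl in place of 1-methyl-1H-imidazol-4-yl on a saturated chain carbon bound to an amine nitrogen in a ring

Within the data shown here, the one measured step that bears on this is the change from compound 1 to compound 2, where a different five-membered heteroaromatic ring took the same place and the result was a 1.6-fold lower number from compound 1 to compound 2 (0.20 log units; within the scatter), within the scatter. That step shows the shared core tolerating an exchange of the ring at this position without a change beyond the scatter. Among the measured compounds shown here, the change to compound 3 keeps the same ring type and adds the butyl and methyl groups named above, for which no measured step exists. The expectation is therefore a step of a 1.1-fold lower number from compound 1 to compound 3 (0.04 log units; within the scatter) in this assay, that is, none beyond the scatter, with wide uncertainty.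

Compound 3 is estimated at 30 nM, ranging from 8 nM to 110 nM.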

Compound 3, half-maximal inhibitory concentration: 46 nM
The estimate for compound 3 lay 1.5-fold (0.19 log units) below the measured number; the measured number falls inside the stated range.
By their numbers in this assay, from the lowest: compounds 2, 1 and 3 (each within the scatter of the next, the first and the last beyond it).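

Replacing 1-methyl-1H-imidazol-4-yl with 1-butyl-5-methyl-1H-imidazol-4-yl takes the group from 6 to 10 heavy atoms, yet it gives a 1.4-fold higher number from compound 1 to compound 3 (0.14 log units; within the scatter) in this assay, so this position accepts the extra carbons without a change that can be read. The same group in place of 2,5-dimethyl-1,3-thiazol-4-yl gives a 2.2-fold higher number from compound 2 to compound 3 (0.34 log units; beyond the scatter), a modest step but the first here that lies beyond the scatter, which shows that the choice of group at this place can shift the number, if only slightly. Nothing available explains either step, and no measurement here speaks to what lies behind them.

From the compounds shown here alone, what the butyl and the added methyl each contribute stays open, as the two enter together and their separate shares cannot be read from these compounds. Also open, going by these compounds, is whether a longer chain such as hexyl, or a chain ending in an amine or a carboxylic acid, would be accepted in place of the butyl.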